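The source may hold more compounds than are shown below. What is called first, only, known or untested is meant among the compounds shown, and "the series" means these compounds.

Three compounds with a shared core differ only in the aromatic group on an amine nitrogen in a ring. In a functional assay on MCF7 cells (Homo sapiens) for antiproliferative activity, read by MTT assay, with a stated time of 72 h (on this read-out higher numbers stand for weaker inhibition and lower numbers for stronger inhibition), compound 1 (`Nc1nc(N)c2cc(CSC(=S)N3CCN(c4ccccc4Cl)CC3)ccc2n1`), carrying 2-chlorophenyl, gives 3190 nM as its result. Compound 2 (`Nc1nc(N)c2cc(CSC(=S)N3CCN(c4ccc(F)cc4)CC3)ccc2n1`), carrying 4-fluorophenyl, gives 1920 nM as its result, and the step between these two is a 1.7-fold lower number from compound 1 to compound 2 (0.22 log units; within the scatter) in size. Compound 3 (`Nc1nc(N)c2cc(CSC(=S)N3CCN(c4ccccn4)CC3)ccc2n1`), carrying pyridin-2-yl, gives 5110 nM as its result. That number cannot be told apart from compound 1 (a 1.6-fold higher number from compound 1 to compound 3 (0.20 log units; within the scatter)), but it does stand apart from compound 2 (a 2.7-fold higher number from compound 2 to compound 3 (0.43 log units; beyond the scatter)), and it is the weaker result of that pair.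

Compound 4 (`Nc1nc(N)c2cc(CSC(=S)N3CCN(c4ncccn4)CC3)ccc2n1`) has pyrimidin-2-yl in place of pyridin-2-yl on an amine nitrogen in a ring. For the measured compounds named here, no measured step makes this exact swap. The nearest evidence is the three steps above, which change the same group, and the largest of them is only modest. A swap between two such closely matched six-membered aromatic rings therefore gives no reason to expect a shift beyond the scatter in this assay, in either direction. The estimated step is a 1.1-fold lower number from compound 3 to compound 4 (0.06 log units; within the scatter) and it is expected to stay within the scatter. For compound 4 the estimate is 4500 nM with an expected range from 1900 nM to 10500 nM around it.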

Compound 4, half-maximal inhibitory concentration: 4190 nM
For compound 4 the middle estimate is 1.1-fold (0.03 log units) above the measured one, within the range that was stated.
By their numbers in this assay, from the lowest: compounds 2, 1, 4 and 3 (each within the scatter of the next, the first and the last beyond it).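

In this assay, adding a second ring nitrogen, as pyrimidin-2-yl in place of pyridin-2-yl, makes no difference that can be read (a 1.2-fold lower number from compound 3 to compound 4 (0.09 log units; within the scatter)), so this extra hetero atom and hydrogen-bond acceptor on the amine nitrogen in a ring does not visibly move the result. Compound 4 also cannot be told apart from the 2-chlorophenyl compound (a 1.3-fold higher number from compound 1 to compound 4 (0.12 log units; within the scatter)), but it does stand apart from the 4-fluorophenyl compound (a 2.2-fold higher number from compound 2 to compound 4 (0.34 log units; beyond the scatter)), so compound 3 and compound 4, the two with ring nitrogens in this group, both give weaker results than compound 2 by a modest step. Nothing measured here explains these small differences.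

On these data alone, all four groups are six-membered aromatic rings, so it remains open whether a non-aromatic cyclohexyl group, a benzyl group or a simple methyl at this place would keep the result in the same range. As far as these compounds go, it is also open whether the edge of compound 2 belongs to the fluorine or to where it sits, which 2-fluorophenyl and 4-chlorophenyl could help to separate.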